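The source may report more compounds than this note shows. Statements on the series, on what has been measured and on what is new or still open speak of the compounds shown alone.

Three compounds share one core and have been measured in a functional assay on MGC-803 cells (Homo sapiens) for inhibition, read by MTT assay, with a stated time of 72 h; a lower number here means a stronger inhibitor, a higher number a weaker inhibitor:

compound 1, `Cc1cc(Nc2cc(-c3ccccc3)[nH]n2)n2nc(SCc3csc4ccccc34)nc2n1`, gives 2280 nM;
compound 2, `Cc1ccc(Cn2ccc(Nc3cc(C)nc4nc(SCc5ccc(Br)cc5)nn34)n2)cc1`, gives 7420 nM;
compound 3, `Cc1cc(Nc2ccn(Cc3ccc(C(F)(F)F)cc3)n2)n2nc(SCc3ccc(Br)cc3)nc2n1`, gives 2590 nM.

Compound 1 has the lowest of these three numbers. Compound 3 sits within the scatter of it, so the two cannot be told apart, while compound 2 lies beyond the scatter above both. Among the compounds with values here, the one step that can be read from the measured set, a 2.9-fold lower number from compound 2 to compound 3 (0.46 log units; beyond the scatter), concerns a substituent on a distant aromatic ring and says nothing about the sulfur-linked arm.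

Compound 4, `C=CCSc1nc2nc(C)cc(Nc3cc(-c4ccccc4)[nH]n3)n2n1`, differs from compound 1 only at that arm: vinyl in place of 1-benzothiophen-3-yl on a saturated chain carbon bound to a sulfur. The bulky bicyclic group that hangs on the sulfur in compound 1 is thus reduced to a short three-carbon chain. Within the data shown here, no measured pair shows what such a pruning does in this assay, so the expectation rests on the size of the loss alone. Removing so much of the molecule is expected to weaken inhibition, and the estimated step is a 2.9-fold higher number from compound 1 to compound 4 (0.45 log units; beyond the scatter). Compound 4 is therefore expected to give about 6500 nM in this assay, with a plausible range from 2200 nM to 20000 nM.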

Compound 4, half-maximal inhibitory concentration: 17200 nM
Compound 4: middle estimate off by 2.6-fold (0.42 log units), on the low side, within the range that was stated.
By their numbers in this assay, from the lowest: compounds 1 and 3 (each within the scatter of the next); then compound 2; then compound 4.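

In this assay, within the data shown here, this is the first measured change at the sulfur-linked arm, and it gives a 7.5-fold higher number from compound 1 to compound 4 (0.88 log units; beyond the scatter), so what sits on the saturated chain carbon bound to the sulfur clearly affects the read-out; the only earlier step, trifluoromethyl in place of methyl on an aromatic carbon, lay elsewhere in the molecule. This single swap does several things at once: 1-benzothiophen-3-yl, with 9 heavy atoms, two aromatic rings and a ring sulfur, leaves, and vinyl, with 2 heavy atoms, no ring and a double bond outside any aromatic ring, enters. No measurement at hand explains the loss, so the step records an outcome and not its cause.

Steps from compound 1 or compound 4 to compound 2 or compound 3 cannot be read, as those pairs differ in more than one place. As far as these compounds go, it remains open whether the higher number follows from losing the rings or from losing one particular feature of 1-benzothiophen-3-yl, and a plain phenyl ring or a longer saturated chain such as n-butyl on the same carbon would help to tell these apart.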